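A few compounds are considered here, and "the series" means these few. Any claim that something is new, unique, unknown or untested is made for them only; others in the source may bear on it.

Measured compounds:
compound 1, `Cc1noc(NS(=O)(=O)c2cccc3cc(N)ccc23)c1C`, in an assay on thoracic aorta for binding affinity to Endothelin-1 receptor (Rattus norvegicus) (a higher number here means a weaker inhibitor, a lower number a stronger inhibitor), gives 2400 nM
compound 2, `Cc1noc(NS(=O)(=O)c2cccc3cc(N(C)C)ccc23)c1C`, in this assay gives 840 nM
compound 3, `Cc1noc(NS(=O)(=O)c2ccc3cccc(N)c3c2)c1C`, in this assay gives 9800 nM

Compounds 1 and 3 have the same atoms joined differently; the difference between the two cores is not broken down here. Of the three, compound 3 gives the highest number, and compound 1 gives a lower one in this assay. From compound 1 to compound 2 the change is dimethylamino in place of amino on an aromatic carbon, and the step was a 2.9-fold lower number from compound 1 to compound 2 (0.46 log units; beyond the scatter). Compound 4, `Cc1noc(NS(=O)(=O)c2ccc3cccc(N(C)C)c3c2)c1C`, has not yet been measured. From compound 3 to compound 4 the change is dimethylamino in place of amino on an aromatic carbon. It is the same kind of change as from compound 1 to compound 2, but the place is not the same: in compound 4 the dimethylamino stands ortho to a fused ring and meta to a fused ring, whereas in compound 2 it stands meta to a fused ring and para to a fused ring. Among the compounds with values here, only one measured step shows this change, so the expectation rests on compound 1 and compound 2 alone. Compound 4 is expected to give about 3500 nM in this assay. The expected step from compound 3 to compound 4 is a 2.8-fold lower number from compound 3 to compound 4 (0.45 log units; beyond the scatter). The range expected for compound 4 is wide, from 1400 nM to 9000 nM. Within the data shown here, the range is wide because the single precedent a 2.9-fold lower number from compound 1 to compound 2 (0.46 log units; beyond the scatter) sits at a different place.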

Compound 4, half-maximal inhibitory concentration: 31500 nM
For compound 4 the middle estimate is 9.0-fold (0.95 log units) below the measured one, outside the stated range (above it).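

In this assay, dimethylamino in place of amino on an aromatic carbon gave a 3.2-fold higher number from compound 3 to compound 4 (0.51 log units; beyond the scatter), so the change did not carry over from the core of compound 1 to the core of compound 3. The two steps run in opposite directions, and the gap between them exceeds what repeated measurements would explain: the same change on two cores in this assay, a 2.9-fold lower number (0.46 log units; beyond the scatter) from compound 1 to compound 2 and a 3.2-fold higher number (0.51 log units; beyond the scatter) from compound 3 to compound 4, 9.2-fold (0.96 log units) apart, beyond the scatter of two such steps. Within the data shown here, this shows that, in this series, the step seen on one core cannot be transferred to the other, but with only two steps it does not show why, and it cannot separate the core itself from the place of the group, which stands ortho to a fused ring and meta to a fused ring in compound 4 but elsewhere in compound 2.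

Going by these compounds, it remains open whether a methylamino or diethylamino group on the same aromatic carbon would follow compound 2 or compound 4. Also open, on these data alone, is what amino and dimethylamino would do at other places on either core.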